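Chain-length series at the cytotoxicity limit, hexyl to butyl

The source may hold more compounds than are shown below. What is called first, only, known or untested is meant among the compounds shown, and "the series" means these compounds.

Compound 3 `CCCCCCNc1cnc(C(=O)NCc2ccccc2)cn1` carries a hexyl chain on the aromatic amine of the shared core. In an ADME assay on HeLa cells (Homo sapiens) for cytotoxicity, read by microscopy, with a stated time of 6 days (on this read-out lower numbers stand for higher toxicity in this test and higher numbers for lower toxicity in this test), compound 3 gives only a limit, > 100000 nM. Its two measured neighbours sit the same way. Compound 1 `CCCCCNc1cnc(C(=O)NCc2ccccc2)cn1`, the pentyl analogue, gives a limit of > 100000 nM in this assay. Compound 2 `CCCCCCCNc1cnc(C(=O)NCc2ccccc2)cn1`, the heptyl analogue, gives a limit of > 100000 nM in this assay. The steps between them are therefore not readable: a step that the two limits leave unreadable from compound 1 to compound 2, a step that the two limits leave unreadable from compound 1 to compound 3 and a step that the two limits leave unreadable from compound 2 to compound 3. Among the measured compounds shown here, what the series does show is the limit of > 100000 nM in this assay, at which 3 of the 3 values shown sit, so no measured step separates any of the three compounds from the others.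

Compound 4 `CCCCNc1cnc(C(=O)NCc2ccccc2)cn1` is the butyl analogue, not yet measured in this assay. The change from compound 3 is hydrogen in place of ethyl on a saturated chain carbon, four bonds along the chain from a nitrogen on an aromatic ring. The measured steps that bear on it, from compound 1 to compound 2 and from compound 1 to compound 3, are chain-length steps of the same kind, and all of them are unreadable because of the limit of > 100000 nM in this assay, at which 3 of the 3 values shown sit. The expectation is that compound 4 also sits at the limit, so the step of a number no higher from compound 3 to compound 4 (the limit leaves the size open) from compound 3 to compound 4 is expected to be none beyond the scatter. For compound 4 the estimate in this assay is 100000 nM, with a range from 50000 nM to 200000 nM, most likely reported again as a limit only.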

Compound 4, minimum cytotoxic concentration: > 100000 nM
Compound 4 was reported as a limit (the forecaster's own chance of this, stated with the estimate: 85%); the middle value lies on the limit itself.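

In this assay compound 4 gives > 100000 nM, which is a limit. No step from compound 1, compound 2 or compound 3 to compound 4 can be read, because all four compounds share one limit: the limit of > 100000 nM in this assay, at which 4 of the 4 values shown sit.

The compounds shown leave open whether chain length from butyl to heptyl changes this read-out at all, and at what concentration any of these compounds turns cytotoxic.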